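Extending the aryl group of compound 1 with a methylpyrazole

The source may hold more compounds than are shown below. What is called first, only, known or untested is meant among the compounds shown, and "the series" means these compounds.

Compound 1 `COc1cc(-c2ccnc3cc(-c4ccc(F)cc4)nn23)cc(OC)c1OC` carries a 4-fluorophenyl group on the shared core. In a functional assay on A549 cells (Homo sapiens) for inhibition, read by CCK-8 assay, with a stated time of 48 h (on this read-out higher numbers stand for weaker inhibition and lower numbers for stronger inhibition), compound 1 gives 3800 nM, the highest number among the three measured compounds. Compound 2 `COc1ccc(-c2cc3nccc(-c4cc(OC)c(OC)c(OC)c4)n3n2)cc1F` gives 545 nM, and compound 3 `COc1ccc(-c2cc3nccc(-c4cc(OC)c(OC)c(OC)c4)n3n2)cc1N` gives 138 nM. The step of a 7.0-fold lower number from compound 1 to compound 2 (0.84 log units; beyond the scatter) is modest, and the step of a 28-fold lower number from compound 1 to compound 3 (1.44 log units; beyond the scatter) is large; the step of a 3.9-fold lower number from compound 2 to compound 3 (0.60 log units; beyond the scatter) shows that the amino group alone accounts for part of that gain.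

Compound 4 `COc1cc(-c2ccnc3cc(-c4ccc(-c5cnn(C)c5)cc4)nn23)cc(OC)c1OC` differs from compound 1 as follows: 1-methyl-1H-pyrazol-4-yl in place of fluoro on an aromatic carbon. Going by the values given here, none of the measured steps makes this same change; the two steps from compound 1 alter the aryl ring at a different place and with smaller groups. They do show that the aryl group of compound 1 tolerates substitution and that both changes lowered the number beyond the scatter, so a lower number is expected here too, though with wide uncertainty. Compound 4 is therefore estimated to give 1200 nM in this assay, in the range 250 nM to 5000 nM, which is an expected step of a 3.2-fold lower number from compound 1 to compound 4 (0.50 log units; beyond the scatter).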

Compound 4, half-maximal inhibitory concentration: 1150 nM
Estimate against measurement, compound 4: 1.0-fold (0.02 log units) above; the measured number falls inside the stated range.
By their numbers in this assay, from the lowest: compound 3; then compound 2; then compound 4; then compound 1.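

In this assay, replacing fluoro with 1-methyl-1H-pyrazol-4-yl gives a 3.3-fold lower number from compound 1 to compound 4 (0.52 log units; beyond the scatter). The aromatic carbon para to a large group, which carries a single fluorine atom in compound 1, therefore accepts a group of six heavy atoms with its own five-membered aromatic ring, and the number falls rather than rises. Unlike the earlier steps from compound 1, which exchanged the whole aryl group, this step changes only the fluoro, although nothing in the data shown accounts for the size of the step.

The compounds shown leave open whether the lower number depends on the pyrazole ring itself, its nitrogen atoms or its methyl group, and how an unmethylated pyrazole, a phenyl ring or a morpholine would compare at this place. They also leave open whether the 1-methyl-1H-pyrazol-4-yl group would add to the effect of the amino group in compound 3, since no compound shown carries both groups.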